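This account rests on a few compounds, and the source may have more. Where it says the series, first, only, none or still open, it means among the compounds named here.

Compound 1 `O=C(NCc1ccccc1Br)N1C(=O)c2ccccc2S1(=O)=O`: 0.253 h
Compound 2 `O=C(NCc1cccc(Br)c1)N1C(=O)c2ccccc2S1(=O)=O`: 0.492 h
Compound 3 `O=C(NCc1ccc(Br)cc1)N1C(=O)c2ccccc2S1(=O)=O`: 0.187 h

In a physicochemical assay for pharmacokinetics (a lower number here means that the compound disappears faster, a higher number that the compound lasts longer), compound 1 gives 0.253 h, a number that cannot be told apart from either of the other two: a 1.9-fold higher number from compound 1 to compound 2 (0.29 log units; within the scatter) and a 1.4-fold lower number from compound 1 to compound 3 (0.13 log units; within the scatter). Within the data shown here, only one measured step leaves the scatter, and modestly: a 2.6-fold lower number from compound 2 to compound 3 (0.42 log units; beyond the scatter).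

Compound 4 `O=C(NCc1ccccc1C(F)(F)F)N1C(=O)c2ccccc2S1(=O)=O` differs from compound 1 in one place: trifluoromethyl in place of bromo on an aromatic carbon. This is trifluoromethyl in place of bromo on an aromatic carbon, ortho to a large group. The measured steps only exchange one bromophenyl for another. None replaces bromo with a different group, so they show only how widely this small series spreads.

In this assay no change beyond the scatter is therefore expected, and the estimated step is a 1.1-fold higher number from compound 1 to compound 4 (0.03 log units; within the scatter). For compound 4 the estimated half-life is 0.27 h, with an expected range from 0.12 h to 0.6 h.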

Compound 4, half-life: 0.187 h
Compound 4: the middle estimate sits 1.4-fold (0.16 log units) above what was measured; low and high end bracket the measured number.
By their numbers in this assay, from the lowest: compounds 3, 4, 1 and 2 (each within the scatter of the next, the first and the last beyond it).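

Trifluoromethyl in place of bromo on an aromatic carbon, ortho to a large group, is the first change here of the group itself rather than of where bromo sits. In this assay it gives a 1.4-fold lower number from compound 1 to compound 4 (0.13 log units; within the scatter), so at this position a group of 4 heavy atoms can replace one of 1 heavy atom with no change that stands out from the scatter. Nothing available here explains this result.

Going by these compounds, whether an amine or a carboxylic acid at this position would shift the half-life remains open. So does how trifluoromethyl would behave where bromo sits in compound 2 and compound 3.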